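The source may hold more compounds than are shown below. What is called first, only, known or untested is meant among the compounds shown, and "the series" means these compounds.

Compound 1 `CCCOC(=O)C1=C(C)NC(=O)NC1c1ccco1` stands level with compound 2 in an assay on membranes from HeLa cells for displacement of a labelled ligand from adenosine receptor A3 (Homo sapiens), read by scintillation counting, with a stated time of 180 min, tested at 1 uM (a higher number here means more inhibition at the concentration tested (going by the name of the read-out), a lower number less inhibition), the two of them together the lowest of three numbers: compound 1 gives 3%. Compound 2 `CC1=C(C(=O)OCc2ccccc2)C(c2ccco2)NC(=O)N1` gives 3%, and compound 3 `CCCOC(=O)C1=C(C)NC(=O)NC1c1ccsc1` gives 6%; the step of no change at the digits printed from compound 1 to compound 2 (within the scatter) and the step of a number 3 percentage points higher from compound 1 to compound 3 (within the scatter) both stay within the scatter. Compound 4 `CCCOC(=O)C1=C(C)N(C)C(=O)NC1c1ccco1` differs from compound 1 by methyl in place of hydrogen on an amide-type nitrogen in a ring. For the measured compounds named here, neither measured step alters the amide-type nitrogen in the ring, so no measured step bears directly on this change; both only show that single replacements have left the read-out near the floor. Because compound 1 gives 3%, compound 4 is expected to show a step of no change at the digits printed from compound 1 to compound 4 (within the scatter), within the scatter. Compound 4 is therefore estimated at 3%, ranging from -5% to 12%.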

Compound 4, a percentage reported as inhibition, at one concentration (the size of the read-out at that concentration, not a potency): 8%
Estimate against measurement, compound 4: 5 percentage points below, and the stated range covers the measured number.
By their numbers in this assay, from the lowest: compounds 1, 2, 3 and 4 (each within the scatter of the next).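

In this assay, for the compounds shown here, the methyl in place of hydrogen on the amide-type nitrogen in a ring, a position no earlier step touched, gives a number 5 percentage points higher from compound 1 to compound 4 (within the scatter) and so leaves the read-out within the scatter. This nitrogen therefore carries a methyl with no gain or loss in inhibition that can be told apart at this concentration. No measurement at hand offers a reason for this result. Going by these compounds, whether an ethyl group or a longer chain on this nitrogen would behave alike stays open. So does whether the methyl would give the same result alongside the thiophen-3-yl group of compound 3.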